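The source may report more compounds than this note shows. Statements on the series, on what has been measured and on what is new or still open speak of the compounds shown alone.

Compound 2 `Cn1ccc2c(Oc3ccc(NC(=O)c4nn(-c5ccc(Cl)cc5)ccc4=O)cc3)ccnc21` was tested in a functional assay on A549 cells (Homo sapiens) for cytotoxicity, read by MTT assay, with a stated time of 72 h (on this read-out higher numbers stand for weaker inhibition and lower numbers for stronger inhibition), where compound 2 gives > 60000 nM, which is a limit of the assay rather than a number. Compound 2 thus sits at the limit of > 60000 nM in this assay, at which 2 of the 3 values shown sit. Compound 1 `O=C(Nc1ccc(Oc2ccnc3[nH]ccc23)c(F)c1)c1nn(-c2ccc(Cl)cc2)ccc1=O` gives > 60000 nM in this assay, again a limit. Compound 3 `Cn1ccc2c(Oc3ccc(NC(=O)c4nn(-c5ccc(Cl)c(C(F)(F)F)c5)ccc4=O)cc3)ccnc21` gives 11400 nM in this assay. One measured step joins these compounds: trifluoromethyl in place of hydrogen on an aromatic carbon gives an at least 5.2-fold lower number from compound 2 to compound 3 (0.72 log units; beyond the scatter). Compound 4 `Cn1ccc2c(Oc3ccc(NC(=O)c4nn(-c5ccc(Cl)cc5)ccc4=O)cc3F)ccnc21` differs from compound 2 by fluoro in place of hydrogen on an aromatic carbon. Among the compounds with values here, no measured step tests a fluoro at this place; the trifluoromethyl step concerns a different group elsewhere and so does not bear directly on it, and compound 1, which also carries a fluoro on an aromatic carbon together with a further change, stays at the limit. A step of no more than the scatter is therefore expected, a number no higher from compound 2 to compound 4 (the limit leaves the size open). Compound 4 is estimated at 60000 nM, between 20000 nM and 150000 nM, with a good chance that only a limit is reported.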

Compound 4, half-maximal inhibitory concentration: > 60000 nM
Compound 4 ended at the assay's limit; the forecaster's own chance of this, stated with the estimate: 70%; the middle value lies on the limit itself.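

In this assay compound 4 gives > 60000 nM, which is a limit of the assay and not a number. Compound 1 and compound 2 also sit at a limit, so neither step to compound 4 can be read. On these data alone, whether the fluoro changes cytotoxicity at all stays open.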